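The compounds below may be only part of what the source reports. "The series", "measured", "known", "first", "only" and "open" are said of these compounds alone.

Measured compounds:
- compound 1 `COc1cc2c(Nc3ccc4sc(C(=O)Nc5c(C)cccc5Cl)cc4c3)ncnc2cc1OCCCN1CCCCC1C`: 80.3%
- compound 2 `CCN(CC)CCCOc1cc2ncnc(Nc3ccc4sc(C(=O)Nc5c(C)cccc5Cl)cc4c3)c2cc1OC`: 78%
- compound 3 `Cc1nc(Nc2ccc3sc(C(=O)Nc4c(C)cccc4Cl)cc3c2)cc(N2CCC(C)CC2)n1`: 24.6%

In a functional assay on U-937 cells (Homo sapiens) for inhibition, read by MTT assay and WST assay, with a stated time of 72 h, tested at 10 uM (a higher number here means more inhibition of growth at the concentration tested, a lower number less inhibition of growth), compound 2 stands second highest of the three. Its value sits within the scatter of compound 1, so the two cannot be told apart, while the value of compound 3, which has a different core, lies far lower, beyond the scatter. Compound 4 `COc1cc2c(Nc3ccc4sc(C(=O)Nc5c(C)cccc5Cl)cc4c3)ncnc2cc1OCCCN1CCN(C)CC1` is not yet measured. It differs from compound 2 in one place: 4-methylpiperazin-1-yl in place of diethylamino on a saturated chain carbon, three bonds along the chain from an oxygen on an aromatic ring. Among the compounds with values here, the only measured step that bears on this change is the one at the same place, a number 2.3 percentage points lower from compound 1 to compound 2 (within the scatter), which swapped one amine for another on the same chain and moved the number only within the scatter. Swapping the amine a second time, this time to a ring, is therefore expected to leave the number essentially where it is, with no step beyond the scatter in either direction. The estimate for compound 4 is accordingly 78%, with a range from 66% to 88%, which corresponds to an expected step of no change at the digits printed from compound 2 to compound 4 (within the scatter).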

Compound 4, percent growth inhibition at one concentration: 76%
The estimate for compound 4 lay 2 percentage points above the measured number; measured number inside the range.
By their numbers in this assay, from the lowest: compound 3; then compounds 4, 2 and 1 (each within the scatter of the next).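

In this assay the end of the chain now carries 4-methylpiperazin-1-yl, a ring with a second nitrogen, and the step reads a number 2 percentage points lower from compound 2 to compound 4 (within the scatter) for this swap from the open-chain diethylamino. Set against the other ring amine, 2-methylpiperidin-1-yl, the reading is a number 4.3 percentage points lower from compound 1 to compound 4 (within the scatter) and so this place, three bonds along the chain from an oxygen on an aromatic ring, has now taken three different amines that cannot be told apart at the concentration tested. No measurement at hand gives a reason for this sameness.

The compounds shown leave open how a carboxylic acid or a morpholine ring would read in place of these amines, and whether a chain shorter or longer than the propyl chain would read the same. They also leave open whether the three amines would still read alike at a lower concentration.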